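This account rests on a few compounds, and the source may have more. Where it says the series, first, only, none or still open, it means among the compounds named here.

Compound 2 `O=C1CCc2cc(-n3cnnc3)ccc2N1Cc1cccc(Cl)c1` stands in a functional assay on the whole organism (strain KunMing) with Mus musculus as the target, in the maximal electroshock model, with a stated time of 4 h (a lower number here means that less compound is needed, a higher number that more compound is needed for the effect), at 300 mg/kg, level with its neighbours. Compound 1 `O=C1CCc2cc(-n3cnnc3)ccc2N1Cc1ccccc1Cl` gives 300 mg/kg in this assay, and compound 3 `CCCCCCCCN1C(=O)CCc2cc(-n3cnnc3)ccc21` gives 300 mg/kg. The three steps among them, no change at the digits printed from compound 1 to compound 2 (within the scatter), no change at the digits printed from compound 1 to compound 3 (within the scatter) and no change at the digits printed from compound 2 to compound 3 (within the scatter), all stay within the scatter even though each exchanges the whole group on the saturated chain carbon bound to the amide-type nitrogen in the ring. Compound 4 `O=C1CCc2cc(-n3cnnc3)ccc2N1Cc1cccc(C(F)(F)F)c1` differs from compound 2 by trifluoromethyl in place of chloro on an aromatic carbon. Within the data shown here, no measured step alters a substituent on the aromatic ring, so the bearing of these steps is indirect; since even larger exchanges left this assay unmoved, no step beyond the scatter is expected for compound 4, that is no change at the digits printed from compound 2 to compound 4 (within the scatter). Compound 4 is therefore estimated at 300 mg/kg, within 150 mg/kg to 600 mg/kg.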

Compound 4, minimum effective dose: 300 mg/kg
Compound 4: middle estimate and measured number agree at the digits printed, and the stated range covers the measured number.
By their numbers in this assay, from the lowest: compounds 1, 2, 3 and 4 (each within the scatter of the next).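

Until now the steps had exchanged only the whole group on the chain carbon, whereas this one alters a substituent on the aromatic ring, and in this assay trifluoromethyl in place of chloro gives no change at the digits printed from compound 2 to compound 4 (within the scatter). The insensitivity seen for the earlier exchanges thus also holds for this single change on the ring. Nothing available explains this result.

From the compounds shown here alone, it remains open whether an amine or a carboxylic acid on this aromatic carbon would leave the reading level. Whether any substituent at another carbon of this ring would move it is also unresolved.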